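Methyl on the piperazine nitrogen of compound 1: Ret series

The source may hold more compounds than are shown below. What is called first, only, known or untested is meant among the compounds shown, and "the series" means these compounds.

Measured so far:
compound 1 `CNc1ncc2c(-c3ccc(N4CCNCC4)nc3)nn(Cc3cn(Cc4ccccc4)nn3)c2n1` gives 600 nM in an assay for inhibition of proto-oncogene tyrosine-protein kinase receptor Ret (Homo sapiens), read by 33P incorporation, in the presence of a further agent that is not named here; a lower number here means a stronger inhibitor, a higher number a weaker inhibitor
compound 2 `CNc1ncc2c(-c3ccc(N4CCNCC4)nc3)nn(Cc3cn(-c4ccsc4C(=O)OC)nn3)c2n1` gives 430 nM
compound 3 `CNc1ncc2c(-c3ccc(N4CCNCC4)cc3)nn(Cc3cn(Cc4ccccc4)nn3)c2n1` reports only a limit of the assay, > 10000 nM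

Compound 1 stands highest of the two numbers given; compound 2 sits a 1.4-fold lower number from compound 1 to compound 2 (0.14 log units; within the scatter) from it, within the scatter. Compound 4 `CNc1ncc2c(-c3ccc(N4CCN(C)CC4)nc3)nn(Cc3cn(Cc4ccccc4)nn3)c2n1` differs from compound 1 by methyl in place of hydrogen on an amine nitrogen in a ring, that is piperazin-1-yl to 4-methylpiperazin-1-yl. Neither measured step touches this ring: the change behind a 1.4-fold lower number from compound 1 to compound 2 (0.14 log units; within the scatter) lies on an aromatic nitrogen far from it, and the change behind an at least 16-fold higher number from compound 1 to compound 3 (1.22 log units; beyond the scatter) swaps the ring that carries the piperazine, a large step with compound 3 sitting at the limit of > 10000 nM in this assay, at which 1 of the 3 values shown sits. Going by the values given here, with no measured step at the amine nitrogen, the expectation is no shift beyond the scatter, no change at the digits printed from compound 1 to compound 4 (within the scatter). Compound 4 is therefore estimated at 600 nM, with a range of 250 nM to 1500 nM.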

Compound 4, half-maximal inhibitory concentration: 900 nM
Beside the measured number, compound 4's estimate is 1.5-fold (0.18 log units) below it, and the stated range covers the measured number.
By their numbers in this assay, from the lowest: compounds 2, 1 and 4 (each within the scatter of the next, the first and the last beyond it). At a limit, above all of these: compound 3.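

Methyl in place of hydrogen on the amine nitrogen of the piperazine gives a 1.5-fold higher number from compound 1 to compound 4 (0.18 log units; within the scatter) and is the first measured step at this nitrogen. The hydrogen there is therefore not needed to keep a number within the scatter of compound 1. Nothing measured here gives a reason for this step.

As far as these compounds go, whether larger groups on this nitrogen, such as ethyl, 2-hydroxyethyl or acetyl, also stay within the scatter of compound 1 remains open. So does whether methyl here behaves alike alongside the 2-(methoxycarbonyl)thiophen-3-yl group of compound 2.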